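A few compounds are considered here, and "the series" means these few. Any claim that something is new, unique, unknown or untested is made for them only; others in the source may bear on it.

Working notes on the series. Among the measured compounds shown here, compound 2 `COc1ccccc1N1CCN(CCCNC(=O)NN(Cc2ccccc2)c2ccc(Cl)cc2)CC1` gives 2.9 nM in an assay on CHO cells for displacement of a labelled ligand from D(4) dopamine receptor (Homo sapiens), read by radioligand binding (on this read-out lower numbers stand for stronger inhibition and higher numbers for weaker inhibition), which is the second highest of the three numbers measured so far. For the measured compounds named here, its nearest neighbour is compound 3 `COc1ccccc1N1CCN(CCCNC(=O)NN(Cc2ccccc2F)c2ccc(Cl)cc2)CC1`, which in this assay gives 2.6 nM; the step of a 1.1-fold lower number from compound 2 to compound 3 (0.05 log units; within the scatter) is the only measured change made on one ring at a time, fluoro in place of hydrogen on an aromatic carbon, and it stays within the scatter. Going by the values given here, the furthest number belongs to compound 1 `COc1ccccc1N1CCN(CCCNC(=O)NN(Cc2ccc(-c3ccccc3)cc2)c2ccc(F)cc2)CC1`, which in this assay gives 5.9 nM; no single-point step links compound 1 to compound 2, so the two values are only set side by side.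

Compound 4 `COc1ccccc1N1CCN(CCCNC(=O)NN(Cc2ccccc2)c2ccc(Cl)cc2Cl)CC1` has not been measured. It differs from compound 2 by chloro in place of hydrogen on an aromatic carbon, placed on an aromatic carbon of a six-membered aromatic ring of carbon only, ortho to a large group and meta to a chloro group; cut one bond further out, the change reads 4-chlorophenyl to 2,4-dichlorophenyl. Among the compounds with values here, the one step on record for a single halogen added to an aromatic carbon, a 1.1-fold lower number from compound 2 to compound 3 (0.05 log units; within the scatter), was within the scatter, so a step of similar size is expected here, with no clear direction: from compound 2 to compound 4 the expected step is a 1.2-fold higher number from compound 2 to compound 4 (0.08 log units; within the scatter). For compound 4 the estimate in this assay is 3.5 nM, within a range from 1.2 nM to 10 nM.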

Compound 4, inhibition constant: 15 nM
Beside the measured number, compound 4's estimate is 4.3-fold (0.63 log units) below it, and the stated range ends below it.
By their numbers in this assay, from the lowest: compounds 3 and 2 (each within the scatter of the next); then compound 1; then compound 4.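

In this assay, the change from 4-chlorophenyl to 2,4-dichlorophenyl shows that a halogen added to an aromatic carbon is not always a change without consequence in this series: a 5.2-fold higher number from compound 2 to compound 4 (0.71 log units; beyond the scatter), whereas a 1.1-fold lower number from compound 2 to compound 3 (0.05 log units; within the scatter). Among the compounds shown here, the new chloro sits on an aromatic carbon ortho to a large group and meta to a chloro group, on the ring that already carries a halogen, so this position is the first place where adding one heavy atom moves the number beyond the scatter, here towards weaker inhibition. No measured property of these compounds bears on the reason for this step.

The two halogen steps differ in both the halogen and the ring, so the compounds shown leave open whether the step belongs to this position or to chloro itself, a question that a fluoro, methyl or methoxy group on this same carbon would address. As far as these compounds go, it also remains open whether the same change would give a step of similar size on the other side chains, such as that of compound 1.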